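Sulfur-linked side chains and cell toxicity in the series

This account rests on a few compounds, and the source may have more. Where it says the series, first, only, none or still open, it means among the compounds named here.

Compound 1 `Cc1nc2nc(SCc3ccc(Cl)cc3)nn2c(N2CC[C@@H](C)[C@@H](N(C)c3ncnc4[nH]ccc34)C2)c1C`, compound 2 `Cc1cc(N2CC[C@@H](C)[C@@H](N(C)c3ncnc4[nH]ccc34)C2)n2nc(SCCc3ccccc3)nc2n1` and compound 3 `CCc1cc(N2CC[C@@H](C)[C@@H](N(C)c3ncnc4[nH]ccc34)C2)n2ncnc2n1` share one core and differ in the group carried on the sulfur, or in the absence of that group. In a toxicity assay on GES1 cells (Homo sapiens) for inhibition, read by MTT assay, with a stated time of 72 h (a lower number here means a stronger inhibitor, a higher number a weaker inhibitor), compound 1 gives 99200 nM. In this assay compound 2 gives 66200 nM, the lowest of the two numbers shown, but compound 1 lies only a step away that falls within the scatter, so the two are not told apart. In this assay compound 3 reaches only a limit, > 100000 nM, and that limit is the one noted in the limit of > 100000 nM in this assay, at which 1 of the 3 values shown sits. All three compounds therefore sit in the weak region of this assay.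

Compound 4 `Cc1cc(N2CC[C@@H](C)[C@@H](N(C)c3ncnc4[nH]ccc34)C2)n2nc(SCc3ccc(C(F)(F)F)cc3)nc2n1` has not been measured. Against compound 2 the change is 4-(trifluoromethyl)phenyl in place of benzyl on a saturated chain carbon bound to a sulfur. Among the compounds with values here, no pair of measured compounds differs in one place, so no measured step gives the size of this change directly. With all measured values near or at the limit, the step is expected to be none beyond the scatter, estimated as a 1.1-fold higher number from compound 2 to compound 4 (0.05 log units; within the scatter). Compound 4 is estimated at 75000 nM in this assay, with a range from 30000 nM to 150000 nM, and a real chance that only a limit is reported.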

Compound 4, half-maximal inhibitory concentration: 17300 nM
The estimate for compound 4 lay 4.3-fold (0.64 log units) above the measured number; the measured number lies below the stated range.
By their numbers in this assay, from the lowest: compound 4; then compounds 2 and 1 (each within the scatter of the next). At a limit, above all of these: compound 3.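

In this assay, within the data shown here, replacing the group on the sulfur gives a 3.8-fold lower number from compound 2 to compound 4 (0.58 log units; beyond the scatter), the only step so far that can be read between compounds differing in one place. The side chain on the sulfur is therefore a position where the number in this series can move, at least for this change, although the step is modest. Among these compounds, the earlier values could not show this, as no two of those compounds differ in one place, and compound 4 now stands well clear of the limit reached elsewhere: the limit of > 100000 nM in this assay, at which 1 of the 4 values shown sits.

The same difference also reads as phenethyl to 4-(trifluoromethyl)benzyl, so the compounds shown do not separate the change in the chain from the trifluoromethyl group on the ring. From the compounds shown here alone, it also remains open whether the number in this assay would follow the same direction with an amine or a carboxylic acid in place of that trifluoromethyl group, or with a longer chain between the sulfur and the ring.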